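The compounds below may be only part of what the source reports. "The series", "measured", "known", "first", "only" and "open" are said of these compounds alone.

Measured values in a functional assay on HT-29 cells (Homo sapiens) for cytotoxicity, read by neutral red uptake, with a stated time of 72 h; on this read-out lower numbers stand for stronger inhibition and higher numbers for weaker inhibition:
Compound 1 `CCCCCCNc1nc(SC(C)C)nc2ncccc12` gives 20200 nM.
Compound 2 `CCCCCCCNc1nc(SC(C)C)nc2ncccc12` gives 24400 nM.
Compound 3 `CCCCCCNc1nc(SCCCC)nc2ncccc12` gives 2800 nM.

Compound 4 `CCCCCCNc1nc(SCCCCC)nc2ncccc12` is not yet measured. It differs from compound 3 by methyl in place of hydrogen on a saturated chain carbon, four bonds along the chain from a sulfur. The same kind of change has already been made once, from compound 1 to compound 2, where it reads (methyl in place of hydrogen on a saturated chain carbon, six bonds along the chain from a nitrogen on an aromatic ring); there the place is six bonds along the chain from a nitrogen on an aromatic ring, whereas here it is four bonds along the chain from a sulfur, so the change is of the same kind but not the same. That earlier step gave a 1.2-fold higher number from compound 1 to compound 2 (0.08 log units; within the scatter). The cores of compound 1 and compound 3 differ by butyl in place of isopropyl on a sulfur, and that step gave a 7.2-fold lower number from compound 1 to compound 3 (0.86 log units; beyond the scatter), the largest movement in the set, leaving compound 3 with the lowest number of the three.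

For compound 4 the expected step in this assay is a 1.3-fold lower number from compound 3 to compound 4 (0.10 log units; within the scatter). This expectation rests on the small step of a 1.2-fold higher number from compound 1 to compound 2 (0.08 log units; within the scatter) and on the lowering seen with the longer sulfur chain in a 7.2-fold lower number from compound 1 to compound 3 (0.86 log units; beyond the scatter), which a further lengthening is not expected to reverse. Compound 4 is accordingly estimated at 2200 nM, with a likely range from 800 nM to 6500 nM.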

Compound 4, half-maximal inhibitory concentration: 18400 nM
The estimate for compound 4 lay 8.4-fold (0.92 log units) below the measured number; the whole stated range lies below it.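

In this assay the change of methyl in place of hydrogen on a saturated chain carbon does not carry from one core to the other as a single fixed step: the same change on two cores in this assay, a 1.2-fold higher number (0.08 log units; within the scatter) from compound 1 to compound 2 and a 6.6-fold higher number (0.82 log units; beyond the scatter) from compound 3 to compound 4, 5.4-fold (0.74 log units) apart, beyond the scatter of two such steps

On the core of compound 3, the step reads as a 6.6-fold higher number from compound 3 to compound 4 (0.82 log units; beyond the scatter) and, measured against the isopropyl compound, pentyl on the sulfur gives a 1.1-fold lower number from compound 1 to compound 4 (0.04 log units; within the scatter) so that, among the three sulfur groups, only butyl stands apart from the others. This does not give a rule for the series, as each step rests on one pair and the two changes sit at different places, four bonds along the chain from a sulfur and six bonds along the chain from a nitrogen on an aromatic ring, which leaves the effect of core and the effect of place inseparable.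

The compounds shown leave open how propyl or hexyl on the sulfur would read. They also leave open whether heptyl on the nitrogen would read the same with butyl on the sulfur as with isopropyl.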